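This account rests on a few compounds, and the source may have more. Where it says the series, first, only, none or still open, it means among the compounds named here.

Working notes on the series, which is followed in a functional assay on UACC-62 cells (Homo sapiens) for inhibition, read by sulforhodamine B assay, with a stated time of 48 h; a lower number here means a stronger inhibitor of growth, a higher number a weaker inhibitor of growth.

Of the compounds shown here, three have numbers so far. Compound 1 `CCOC(=O)C(=Cc1c(-c2ccccc2)[nH]c2ccccc12)C(=O)OCC` gives 4600 nM in this assay. Compound 3 `COc1ccc2[nH]c(-c3ccccc3)c(C=C(C#N)C#N)c2c1` gives 2500 nM. Compound 2 `O=C(/C(=C\c1c(-c2ccccc2)[nH]c2ccccc12)S(=O)(=O)c1ccccc1)c1ccccc1` gives 9000 nM, the highest of the three numbers: against compound 1 the gap is within the scatter, so no order between those two is claimed, while against compound 3 the gap lies beyond the scatter.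

The next compound to be measured is compound 4 `N#C/C(=C\c1c(-c2ccccc2)[nH]c2ccccc12)S(=O)(=O)c1ccccc1`. Its difference from compound 2 is cyano in place of benzoyl on a double-bonded chain carbon bound to a double-bonded chain carbon and a sulfonyl sulfur. Within the data shown here, no step between measured compounds stands in this set, so the size of this step is untested. Compound 3, which carries two cyano groups on its double-bonded chain carbon, gives the lowest number of the three, and on that ground the cyano entering in compound 4 is expected to move the number downward from compound 2 by a modest amount, plausibly beyond the scatter but not by much.

The expected step is a 1.8-fold lower number from compound 2 to compound 4 (0.26 log units; within the scatter). Compound 4 is estimated at 5000 nM, with a range from 2000 nM to 15000 nM.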

Compound 4, concentration for 50% growth inhibition: 2600 nM
Compound 4: middle estimate off by 1.9-fold (0.28 log units), on the high side; measured number inside the range.
By their numbers in this assay, from the lowest: compounds 3, 4, 1 and 2 (each within the scatter of the next, the first and the last beyond it).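

In this assay, among these compounds, cyano in place of benzoyl on a double-bonded chain carbon bound to a double-bonded chain carbon and a sulfonyl sulfur gives a 3.5-fold lower number from compound 2 to compound 4 (0.54 log units; beyond the scatter), the first single-place step. This position therefore responds to substitution, and the benzoyl group with its six-membered aromatic ring is not needed here for growth inhibition, as the lower number comes with the far smaller cyano group. No measurement at hand accounts for the size of this step.

One step cannot separate the effect of adding cyano from that of removing benzoyl. An acetyl group or a carboxylic acid at this same place would test whether the lower number is particular to cyano or extends to other small groups.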